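The source may hold more compounds than are shown below. What is called first, only, known or untested is meant among the compounds shown, and "the series" means these compounds.

Compound 1 `CC(C)CN(NC(=O)OCc1ccccc1)C(=O)CN(Cc1ccccc1)NC(=O)CBr`: 1300 nM
Compound 2 `CC(C)CN(NC(=O)OCc1ccccc1)C(=O)CN(Cc1ccccc1)NC(=O)Cc1cccc(Br)c1`: 30000 nM
Compound 3 `CC(C)CN(CC(=O)N(CC(C)C)NC(=O)OCc1ccccc1)/N=C/c1ccccc1B(O)O`: 16200 nM

All three numbers come from a functional assay on L1210 cells (Mus musculus) for inhibition; a higher number here means a weaker inhibitor, a lower number a stronger inhibitor. Compound 3, at 16200 nM, lies within the usual scatter of compound 2, at 30000 nM, and well above compound 1, at 1300 nM.

Compound 4 `CC(C)CN(NC(=O)OCc1ccccc1)C(=O)CN(Cc1ccccc1)/N=C/c1ccccc1B(O)O` differs from compound 3 in one place: phenyl in place of isopropyl on a saturated chain carbon bound to an amine nitrogen. In words, this is phenyl in place of isopropyl on a saturated chain carbon bound to an amine nitrogen, which can also be read as isobutyl to benzyl.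

Going by the values given here, no measured step touches this place. Among the compounds with values here, the only step available, a 23-fold higher number from compound 1 to compound 2 (1.36 log units; beyond the scatter), exchanges a different group, so it says nothing about the direction of this change. It does show that a single exchange in this family can be large, which argues for a wide range. Within the data shown here, compound 1 and compound 2 both carry the benzyl, but no measured pair compares it with isobutyl.

With no direct evidence, no step beyond the scatter is expected in this assay, in either direction. The expected step is small: a 1.4-fold lower number from compound 3 to compound 4 (0.13 log units; within the scatter).

For compound 4 the estimated value is 12000 nM, with an expected range from 3500 nM to 35000 nM.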

Compound 4, half-maximal inhibitory concentration: 27900 nM
The estimate for compound 4 lay 2.3-fold (0.37 log units) below the measured number, within the range that was stated.
By their numbers in this assay, from the lowest: compound 1; then compounds 3, 4 and 2 (each within the scatter of the next).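

In this assay, the exchange of isobutyl for benzyl on this amine nitrogen gives a 1.7-fold higher number from compound 3 to compound 4 (0.24 log units; within the scatter), so the two groups cannot be told apart at this position when the boron-bearing group is present on the other amine nitrogen. With the benzyl held constant, exchanging the group that carries the 3-bromophenyl for the boron-bearing group gives a 1.1-fold lower number from compound 2 to compound 4 (0.03 log units; within the scatter), whereas exchanging the short bromo-bearing group for the same boron-bearing group gives a 21-fold higher number from compound 1 to compound 4 (1.33 log units; beyond the scatter), which places compound 4 with compound 2 and well apart from compound 1. No supporting measurement offers an explanation for these numbers.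

Going by these compounds, only isobutyl and benzyl appear at this position, so it remains open whether a methyl, a longer chain or a benzyl ring carrying an amine or a carboxylic acid would move the number beyond the scatter. On these data alone, it is also open whether the exchange of isobutyl for benzyl would stay this small in a compound carrying the short bromo-bearing group of compound 1.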